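Adding Trifluoromethyl to Compound 2: Expected Tolerance

The compounds below may be only part of what the source reports. "The series", "measured", "known", "first", "only" and "open" are said of these compounds alone.

Compound 2 `O=C(CN1CCCC1)Nc1ccc(-c2nc3ccccc3[nH]2)cc1` has the highest of the two numbers measured in an ADME assay on BHK cells (Mesocricetus auratus) for cytotoxicity, read by MTT assay, with a stated time of 96 h (a higher number here means that more compound is tolerated, a lower number that less compound is tolerated), giving 55000 nM. Compound 1 `Cn1c(-c2ccc(NC(=O)CN3CCCC3)cc2)nc2cc(C(F)(F)F)ccc21`, which also carries a trifluoromethyl group on the shared core, gives 27000 nM in this assay; beyond those two values nothing is known about that pair. Compound 3 `O=C(CN1CCCC1)Nc1ccc(-c2nc3cc(C(F)(F)F)ccc3[nH]2)cc1` differs from compound 2 by trifluoromethyl in place of hydrogen on an aromatic carbon. Because compound 1 gives 27000 nM, compound 3 is expected to be tolerated somewhat less, a modest step of a 1.6-fold lower number from compound 2 to compound 3 (0.20 log units; within the scatter). Compound 3 is estimated at 35000 nM in this assay, within 15000 nM to 80000 nM.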

Compound 3, half-maximal cytotoxic concentration: 29000 nM
For compound 3 the middle estimate is 1.2-fold (0.08 log units) above the measured one, within the range that was stated.
By their numbers in this assay, from the lowest: compounds 1, 3 and 2 (each within the scatter of the next, the first and the last beyond it).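

Swapping hydrogen for trifluoromethyl on this aromatic carbon, a change that could be read on its own for the first time, gives a 1.9-fold lower number from compound 2 to compound 3 (0.28 log units; within the scatter) in this assay, so this change cannot be told apart from repeat-measurement noise. Hydrogen in place of methyl on the aromatic nitrogen gives a 1.1-fold higher number from compound 1 to compound 3 (0.03 log units; within the scatter) and likewise stays inside that noise. No evidence here accounts for these numbers. Going by these compounds, whether a smaller group such as chlorine or a nitrile on the same carbon would give a step beyond the scatter remains open, as does trifluoromethyl on another carbon of that ring.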